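The source may report more compounds than this note shows. Statements on the series, on what has been measured and on what is new or still open speak of the compounds shown alone.

Of the compounds shown here, two sharing one core have been tested in a functional assay on the whole organism (Abdomen, strain Swiss albino) with Mus musculus as the target, with stated times of 10 min and 5 min, at a dose of 15 mg/kg by the oral route; on this read-out higher numbers stand for a stronger effect at the one dose given and lower numbers for a weaker effect. Compound 1, `CCOC(=O)c1onc(-c2cn(-c3ccccc3)nc2-c2ccc(Br)cc2)c1C(=O)OCC`, gives 12.9% in this assay. Among the measured compounds shown here, compound 2, `CCOC(=O)c1onc(-c2cn(-c3ccccc3)nc2-c2ccc(OC)cc2)c1C(=O)OCC`, gives 11.4% in this assay, a number that lies within the scatter of the one from compound 1; the single measured step, a number 1.5 percentage points lower from compound 1 to compound 2 (within the scatter), stayed within the scatter.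

Compound 3, `CCOC(=O)c1onc(-c2cn(-c3ccccc3)nc2-c2ccc(Cl)cc2)c1C(=O)OCC`, has not yet been measured. It differs from compound 2 by chloro in place of methoxy on an aromatic carbon. For the measured compounds named here, the only step that bears on this change is a number 1.5 percentage points lower from compound 1 to compound 2 (within the scatter), which swapped a halogen for methoxy without a shift beyond the scatter, and compound 1, which carries the other halogen, gave 12.9%. A return to a halogen is therefore expected to bring no step beyond the scatter, a number 1.1 percentage points higher from compound 2 to compound 3 (within the scatter). Compound 3 is estimated to give 12.5% in this assay, with a range from 4% to 21%.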

Compound 3, a percentage reported as activity, at one dose (the size of the read-out at that dose, not a potency): 17.3%
Estimate against measurement, compound 3: 4.8 percentage points below, within the range that was stated.
By their numbers in this assay, from the lowest: compounds 2, 1 and 3 (each within the scatter of the next).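

Chloro at this place, on the six-membered aromatic ring and para to a large group, brings no separation from the earlier compounds in this assay: the change from 4-methoxyphenyl to 4-chlorophenyl gave a number 5.9 percentage points higher from compound 2 to compound 3 (within the scatter) and the exchange of bromo for chloro gave a number 4.4 percentage points higher from compound 1 to compound 3 (within the scatter) at the same place. With three groups now compared there, neither exchange of one halogen for the other nor of methoxy for a halogen has produced a step beyond the scatter, so the read-out does not tell these groups apart. No evidence on hand accounts for these numbers.

Open, as far as these compounds go, is whether a group of another kind at this place, such as an amine, a carboxylic acid or a longer chain, would move the read-out beyond the scatter. Also open, from the compounds shown here alone, is what exchanging the two ethyl esters on the shared core would do.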